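This account rests on a few compounds, and the source may have more. Where it says the series, first, only, none or still open, it means among the compounds named here.

In an ADME assay on microsomes from liver (Rattus norvegicus) for metabolic stability, with a stated time of 60 min (on this read-out higher numbers stand for a more stable compound and lower numbers for a less stable compound), three compounds give a first picture of how much of each survives. Compound 1 (`O=C(O)c1cc(-c2cccc(COc3ccc4c(=O)n(C5CCCC5)oc4c3)c2)ccc1Cl`) gives 35%, and compound 3 (`O=C(O)c1cc(-c2cccc(COc3ccc4c(c3)CCN(C3CCCC3)C4=O)c2)ccc1Cl`) gives 36%, so these two lie within the usual scatter of each other. Compound 2 (`CC(C)N1Cc2cc(OCc3cccc(-c4ccc(Cl)c(C(=O)O)c4)c3)ccc2C1=O`) stands apart with 91%, the highest of the three numbers and well beyond the scatter from both of the others.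

The next compound is a close relative of compound 2. Compound 4 (`CCCN1Cc2cc(OCc3cccc(-c4ccc(Cl)c(C(=O)O)c4)c3)ccc2C1=O`) has propyl in place of isopropyl on an amide-type nitrogen in a ring, and the counted difference is propyl in place of isopropyl on an amide-type nitrogen in a ring. The two compounds have the same atoms, joined differently. Going by the values given here, no measured pair here isolates a change of this kind, so the data give no direct size for this step, and any expectation is uncertain. Starting from 91% for compound 2, there is little room to rise, so a fall is the likelier direction. The expected change is a number 19 percentage points lower from compound 2 to compound 4 (beyond the scatter), a moderate drop that would probably lie beyond the scatter. In this assay, the estimate for compound 4 is 72%, with an expected range from 48% to 92%.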

Compound 4, percent of the compound remaining: 96%
The estimate for compound 4 lay 24 percentage points below the measured number; measured number above the stated range.
By their numbers in this assay, from the lowest: compounds 1 and 3 (each within the scatter of the next); then compounds 2 and 4 (each within the scatter of the next).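

In this assay, going by these compounds alone, this is the first pair of compounds that differ in one place only, so a single change can now be read on its own. Putting propyl in place of isopropyl on an amide-type nitrogen in a ring gives a number 5 percentage points higher from compound 2 to compound 4 (within the scatter), which means that on this read-out the two chains cannot be told apart in this pair, even though the atoms of the chain are joined differently. Both chains therefore fit a high share of compound remaining on this core, but no measurement shown here bears on what lies behind that result.

The compounds shown leave open how far this tolerance extends at the same position: a longer chain such as butyl, or a chain ending in an amine, could keep the share remaining as high or could lower it clearly. On these data alone, it also remains open whether swapping propyl and isopropyl would give the same outcome on a different core, since this single pair speaks only for the core shared by compound 2 and compound 4.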